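Swapping a Sulfonate for a Fluorophenyl Ring

A few compounds are considered here, and "the series" means these few. Any claim that something is new, unique, unknown or untested is made for them only; others in the source may bear on it.

Measured so far:
- compound 1, `COc1ccc(C#Cc2csc(C)n2)cn1`: 426 nM
- compound 2, `Cc1nc(C#Cc2ccc(OS(C)(=O)=O)nc2)cs1`: 2340 nM

In a functional assay on CHO cells for agonist activity at metabotropic glutamate receptor 5 (Homo sapiens), read by inositol phosphate accumulation (a lower number here means a stronger inhibitor, a higher number a weaker inhibitor), compound 2 gives the highest number of the two, and the nearest is compound 1 at 426 nM. For the measured compounds named here, the one measured step, a 5.5-fold higher number from compound 1 to compound 2 (0.74 log units; beyond the scatter), concerns a change on the oxygen and does not involve the ring carbon altered here. Compound 3, `Cc1nc(C#Cc2ccc(-c3ccc(F)cc3)nc2)cs1`, differs from compound 2 by 4-fluorophenyl in place of (methylsulfonyl)oxy on an aromatic carbon. Going by the values given here, no measured step bears on this replacement, so the direction is uncertain. The estimate for compound 3 is 600 nM (range 100 nM to 3500 nM), an expected step of a 3.9-fold lower number from compound 2 to compound 3 (0.59 log units; beyond the scatter).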

Compound 3, half-maximal inhibitory concentration: 10.2 nM
For compound 3 the middle estimate is 59-fold (1.77 log units) above the measured one; the whole stated range lies above it.
By their numbers in this assay, from the lowest: compound 3; then compound 1; then compound 2.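

On this carbon next to the ring nitrogen, a directly attached aromatic ring does far better in this assay than either oxygen-linked group. Replacing the (methylsulfonyl)oxy group with 4-fluorophenyl gives a 230-fold lower number from compound 2 to compound 3 (2.36 log units; beyond the scatter), and replacing methoxy with it gives a 42-fold lower number from compound 1 to compound 3 (1.62 log units; beyond the scatter), so compound 3 has the lowest number of the three. No available evidence explains this gain. From the compounds shown here alone, what a plain phenyl ring, a pyridyl ring or an amine would do on this carbon remains open, as does how much of the gain belongs to the fluorine rather than to the ring.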